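The compounds below may be only part of what the source reports. "The series", "measured", "known", "first", "only" and "open" are said of these compounds alone.

Compound 3 `COc1ccc([C@@H]2CC(=O)c3c(O)cc(OCc4cn(C)nn4)cc3O2)cc1O` gives 15200 nM in a functional assay on RAW264.7 cells (Mus musculus) for inhibition, read by Griess assay, with stated times of 2 h and 24 h; on this read-out lower numbers stand for stronger inhibition and higher numbers for weaker inhibition; of the three numbers shown it is the highest, although compound 1 `C=CCn1cc(COc2cc(O)c3c(c2)O[C@H](c2ccc(OC)c(O)c2)CC3=O)nn1`, with 13800 nM, differs from it by a 1.1-fold higher number from compound 1 to compound 3 (0.04 log units; within the scatter), a gap within the scatter, whereas compound 2 `COc1ccc([C@@H]2CC(=O)c3c(O)cc(OCc4cn(Cc5ccccc5Cl)nn4)cc3O2)cc1O`, with 6140 nM, lies clearly below it, as a 2.5-fold higher number from compound 2 to compound 3 (0.39 log units; beyond the scatter) shows. Compound 4 `COc1ccc([C@@H]2CC(=O)c3c(O)cc(OCc4cn(Cc5ccc(F)cc5)nn4)cc3O2)cc1O` is the next step from compound 3: 4-fluorophenyl in place of hydrogen on a saturated chain carbon bound to an aromatic nitrogen. Among the measured compounds shown here, two measured steps bear on this change. The one that ran a 2.5-fold higher number from compound 2 to compound 3 (0.39 log units; beyond the scatter) removed an aryl group from this same carbon and raised the number; the one that ran a 2.2-fold lower number from compound 1 to compound 2 (0.35 log units; beyond the scatter) put an aryl group there and lowered it. Both were modest in size and both point the same way, so placing an aryl group on this carbon in compound 4 is expected to lower the number by a modest margin, the estimated step being a 2.2-fold lower number from compound 3 to compound 4 (0.34 log units; beyond the scatter). Compound 4 is therefore expected to give about 7000 nM in this assay, within a range from 3500 nM to 14000 nM.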

Compound 4, half-maximal inhibitory concentration: 15100 nM
Compound 4: middle estimate off by 2.2-fold (0.33 log units), on the low side; measured number outside the range, above it.
By their numbers in this assay, from the lowest: compound 2; then compounds 1, 4 and 3 (each within the scatter of the next).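

In this assay, an aryl group on this saturated chain carbon bound to an aromatic nitrogen does not by itself bring the number down: 4-fluorophenyl in place of hydrogen gives a 1.0-fold lower number from compound 3 to compound 4 (0.00 log units; within the scatter), and 4-fluorophenyl in place of vinyl gives a 1.1-fold higher number from compound 1 to compound 4 (0.04 log units; within the scatter). The two aryl groups shown do not read alike, as 4-fluorophenyl in place of 2-chlorophenyl gives a 2.5-fold higher number from compound 2 to compound 4 (0.39 log units; beyond the scatter), so among these four compounds only compound 2 stands apart from the rest. Nothing measured here accounts for this difference between the two aryl groups.

The compounds shown leave open whether the lower number of compound 2 goes with the chlorine atom or with its place on the ring, which a 4-chlorophenyl or 2-fluorophenyl group on this carbon would separate. Also open, on these data alone, is how a group of another kind would read here, such as an amine or a carboxylic acid at the end of a longer chain.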